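Methyl addition on the fused ring of compound 2

This account rests on a few compounds, and the source may have more. Where it says the series, first, only, none or still open, it means among the compounds named here.

Within the data shown here, compound 1 `O=C1/C(=C\c2cccc(Br)c2)c2ccccc2N1c1c(Cl)cccc1Cl` is the only member of this set with a number: in a functional assay on L132 cells (Homo sapiens) for cytotoxicity, read by MTT assay, with a stated time of 72 h (a lower number here means that less compound is needed, a higher number that more compound is needed for the effect), compound 1 gives 19 ug/mL. Compound 2 `Cc1ccc2nc(Cl)c(/C=C3\C(=O)N(c4c(Cl)cccc4Cl)c4ccccc43)cc2c1` has no result in this assay, where compound 2 is entered as "not determined" (no result reported). Compound 3 `O=C1/C(=C\c2cc3ccccc3nc2Cl)c2ccccc2N1c1c(Cl)cccc1Cl` likewise has none, entered as "not determined" (no result reported), so compound 2 stands without any number of its own and without a measured neighbour that differs in one place. Compound 4 `Cc1ccc2nc(Cl)c(/C=C3\C(=O)N(c4c(Cl)cccc4Cl)c4ccccc43)cc2c1C` is the next candidate. Its change from compound 2 is methyl in place of hydrogen on an aromatic carbon. Among the measured compounds shown here, no comparison between measured compounds supports a direction, so the step in this assay is expected to stay within the scatter, with no preferred direction. Taking compound 1 as the only anchor, compound 4 is estimated at 20 ug/mL, in the range 6 ug/mL to 70 ug/mL.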

Compound 4, concentration for half-maximal effect: 98 ug/mL
Compound 4: the middle estimate sits 4.9-fold (0.69 log units) below what was measured; measured number above the stated range.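

No step can be read between compound 2 and compound 4: compound 2 has no single number. The compounds shown leave open what the added methyl changes on its own. No supporting data bear on this result.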